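The source may report more compounds than this note shows. Statements on the series, on what has been measured and on what is new or still open speak of the compounds shown alone.

Measured compounds:
compound 1 `OC[C@H]1O[C@@H](n2cnc3c(SCc4ccccc4Br)ncnc32)[C@H](O)[C@@H]1O`: 151 nM
compound 2 `OC[C@H]1O[C@@H](n2cnc3c(SCc4ccc(Br)cc4)ncnc32)[C@H](O)[C@@H]1O`: 11.5 nM

Compound 2 gives the lowest of the two numbers in an assay on isolated protein for inhibition of Equilibrative nucleoside transporter 1 (Homo sapiens); on this read-out higher numbers stand for weaker inhibition and lower numbers for stronger inhibition; compound 1 stands a 13-fold lower number from compound 1 to compound 2 (1.12 log units; beyond the scatter) away from it. Compound 3 `N#Cc1ccccc1CSc1ncnc2c1ncn2[C@@H]1O[C@H](CO)[C@@H](O)[C@H]1O` is not yet measured; the change from compound 2 is 2-cyanophenyl in place of 4-bromophenyl on a saturated chain carbon bound to a sulfur. Among the compounds with values here, the only step that bears on it is a 13-fold lower number from compound 1 to compound 2 (1.12 log units; beyond the scatter), which exchanged the same ring for one carrying a 2-substituent to a 4-substituent and gave a large shift. The reverse exchange here is expected to raise the number; compound 3 is estimated at 100 nM, range 30 nM to 400 nM, a step of an 8.7-fold higher number from compound 2 to compound 3 (0.94 log units; beyond the scatter).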

Compound 3, inhibition constant: 38.9 nM
Compound 3: the middle estimate sits 2.6-fold (0.41 log units) above what was measured, and the stated range covers the measured number.
By their numbers in this assay, from the lowest: compound 2; then compound 3; then compound 1.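

In this assay, cyano in place of bromo on an aromatic carbon gives (a 3.9-fold lower number from compound 1 to compound 3 (0.59 log units; beyond the scatter)), so with the ring substituent at the same place, the group itself changes the number. 2-cyanophenyl in place of 4-bromophenyl gives (a 3.4-fold higher number from compound 2 to compound 3 (0.53 log units; beyond the scatter)), but this step changes both the group and its place on the ring, and the two effects cannot be separated. Nothing available explains either shift.

Still open, going by these compounds, is whether 4-cyanophenyl would match or better 4-bromophenyl. Also open, on these data alone, is how an amine, a carboxylic acid or a longer chain at this place would read.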